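Shortening the octyl chain to a hydroxypropyl group

The source may report more compounds than this note shows. Statements on the series, on what has been measured and on what is new or still open speak of the compounds shown alone.

The study measures three compounds in an ADME assay on PC-3 cells (Homo sapiens) for cytotoxicity, read by sulforhodamine B assay, with a stated time of 48 h, tested at 10 uM; on this read-out lower numbers stand for less inhibition and higher numbers for more inhibition at the one concentration tested (going by the name of the read-out). Compound 1 `COc1nc2ccc(Br)cc2cc1C(c1ccccc1)n1cc(-c2ccccc2F)nn1` gives 13.4%, and compound 2 `COc1nc2ccc(Br)cc2cc1C(c1ccccc1)n1cc(-c2cccc(F)c2)nn1` gives 14.6%; the two differ only in the position of the fluorine, and the step of a number 1.2 percentage points higher from compound 1 to compound 2 (within the scatter) is within the scatter. Compound 3 `CCCCCCCCc1cn(C(c2ccccc2)c2cc3cc(Br)ccc3nc2OC)nn1` gives 2.27% and stands lowest of the three numbers: the step of a number 11.1 percentage points lower from compound 1 to compound 3 (beyond the scatter) and the step of a number 12.3 percentage points lower from compound 2 to compound 3 (beyond the scatter) both lie beyond the scatter, so replacing either fluorophenyl group with an octyl chain reduced inhibition modestly.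

Compound 4 `COc1nc2ccc(Br)cc2cc1C(c1ccccc1)n1cc(CCCO)nn1` has not been measured. It differs from compound 3 by hydroxy in place of pentyl on a saturated chain carbon, three bonds along the chain from an aromatic carbon. Among the measured compounds shown here, no measured pair shows this change, so the two octyl steps are the only guide, and they show only that compound 3 sits well below the two aryl compounds. Because compound 3 gives 2.27% and the aryl compounds give 13.4% for compound 1 and 14.6% for compound 2, the account expects the number for compound 4 to fall between those two levels, nearer the lower one. The step of a number 5.7 percentage points higher from compound 3 to compound 4 (within the scatter) is therefore expected to be small and within the scatter. The estimate for compound 4 in this assay is 8%, with a range from -2% to 20%.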

Compound 4, a percentage reported as inhibition, at one concentration (the size of the read-out at that concentration, not a potency): 14.7%
Compound 4: the middle estimate sits 6.7 percentage points below what was measured; measured number inside the range.
By their numbers in this assay, from the lowest: compound 3; then compounds 1, 2 and 4 (each within the scatter of the next).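

In this assay, the change from octyl to 3-hydroxypropyl gives a number 12.4 percentage points higher from compound 3 to compound 4 (beyond the scatter), so the low number seen with octyl does not extend to every saturated chain at this place on the triazole-bearing side of the shared core. The earlier steps shown here set octyl against two fluorophenyl groups and could not tell whether an aromatic ring at this place was needed to reach their level. The steps of a number 0.1 percentage points higher from compound 2 to compound 4 (within the scatter) and a number 1.3 percentage points higher from compound 1 to compound 4 (within the scatter) now show, for these compounds, that 3-hydroxypropyl reaches the same level without a ring. Nothing measured here gives a reason for the step from octyl to 3-hydroxypropyl.

That step shortens the chain and adds a hydroxy group in a single change, so the compounds shown leave open which of the two matters; a plain propyl chain, or an octyl chain ending in hydroxy, would pull them apart. They also leave open whether the hydroxy group can give way to another end group on the same chain, such as an amine or a carboxylic acid, with the number staying at this level.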